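Pyrazole urea series: removing the pyrazole methyl on the diamine linker

This account rests on a few compounds, and the source may have more. Where it says the series, first, only, none or still open, it means among the compounds named here.

Measured so far in an assay on membranes from brain for binding affinity to Fatty-acid amide hydrolase 1 (Mus musculus), read by fluorescence, with stated times of 1 h and 30 min; a lower number here means a stronger inhibitor, a higher number a weaker inhibitor:
Compound 1, `Cc1cnn(C(=O)NCc2ccc(OCc3ccccc3)cc2)c1`, gives 1200 nM.
Compound 2, `O=C(N1CCCN(Cc2ccc(OCc3ccccc3)cc2)CC1)n1cccn1`, gives 450 nM.
Compound 3, `Cc1cnn(C(=O)N(C)CCN(C)Cc2ccc(OCc3ccccc3)cc2)c1`, gives 8700 nM.

In this assay compound 3 stands highest of the three numbers; the gap to compound 1 and the larger gap to compound 2 both lie beyond the usual scatter. Compound 4, `CN(CCN(C)C(=O)n1cccn1)Cc1ccc(OCc2ccccc2)cc1`, differs from compound 3 by hydrogen in place of methyl on an aromatic carbon. Among the measured compounds shown here, no measured pair isolates this change, so its effect rests only on the fact that compound 2, which carries the 1H-pyrazol-1-yl on another linker, gives the lowest number here. A step of modest size toward a lower number is expected, a 1.7-fold lower number from compound 3 to compound 4 (0.24 log units; within the scatter). Compound 4 is estimated at 5000 nM, between 1500 nM and 15000 nM.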

Compound 4, half-maximal inhibitory concentration: 510 nM
Compound 4: the middle estimate sits 9.8-fold (0.99 log units) above what was measured; the measured number lies below the stated range.
By their numbers in this assay, from the lowest: compounds 2 and 4 (each within the scatter of the next); then compound 1; then compound 3.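

In this assay, among the compounds shown here, the change from 4-methyl-1H-pyrazol-1-yl to 1H-pyrazol-1-yl gives a 17-fold lower number from compound 3 to compound 4 (1.23 log units; beyond the scatter) and is the first measured pair to isolate this position. On this linker, then, the methyl on this aromatic carbon carries a large penalty. Nothing available accounts for the size of this step.

On these data alone, compound 1 and compound 2 have no partners differing only at this position, so whether the same step holds on their linkers stays open. Also open, as far as these compounds go, is how an ethyl group, a chlorine atom or a nitrile would read at this carbon.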